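The source may report more compounds than this note shows. Statements on the series, on what has been measured and on what is new or still open speak of the compounds shown alone.

The measured compounds and their numbers in a functional assay on MV4-11 cells (Homo sapiens) for antiproliferative activity, with a stated time of 6 days, tested at 1.56 uM (on this read-out higher numbers stand for a stronger effect at the one concentration tested and lower numbers for a weaker effect), are:

compound 1, `CNC(=O)N1CCCc2ccc(NC(=O)c3ccc(-c4ccncc4)cc3)cc21`: 37.6%
compound 2, `CNC(=O)N1CCCc2ccc(NC(=O)c3cccc(-c4cc[nH]n4)c3)cc21`: 27.3%
compound 3, `CNC(=O)N1CCCc2ccc(NC(=O)c3ccc(-c4ccn(S(C)(=O)=O)n4)cc3)cc21`: 8.81%

Compound 2 stands second of the three in this assay. Its number lies below that of compound 1 and above that of compound 3, and both gaps are beyond the usual scatter of repeated measurements.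

The compound now in question is compound 4, `CNC(=O)N1CCCc2ccc(NC(=O)c3cccc(-c4cnn(C(C)=O)c4)c3)cc21`. It differs from compound 2 in one place: 1-acetyl-1H-pyrazol-4-yl in place of 1H-pyrazol-3-yl on an aromatic carbon.

Among the compounds with values here, only one measured step bears on this change. Going from compound 1 to compound 3, a 1-(methylsulfonyl)-1H-pyrazol-3-yl replaced a pyridin-4-yl on an aromatic carbon, and the result was a number 28.8 percentage points lower from compound 1 to compound 3 (beyond the scatter). That step is not the same exchange, since it also swaps a six-membered ring for a five-membered one, but it is the only case shown in which the pyrazole nitrogen carries a substituent instead of a hydrogen, and the number fell clearly. On that basis compound 4 is expected to come in lower than compound 2, with an estimated step of a number 15.3 percentage points lower from compound 2 to compound 4 (beyond the scatter) in this assay. The estimate for compound 4 is 12%, with a range from -3% to 28%.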

Compound 4, a percentage reported as inhibition, at one concentration (the size of the read-out at that concentration, not a potency): 33.6%
Beside the measured number, compound 4's estimate is 21.6 percentage points below it; measured number above the stated range.
By their numbers in this assay, from the lowest: compound 3; then compounds 2, 4 and 1 (each within the scatter of the next, the first and the last beyond it).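

In this assay the exchange on this aromatic carbon, meta to a large group, gives a number 6.3 percentage points higher from compound 2 to compound 4 (within the scatter) and so leaves the read-out where it was within the usual scatter. The entering 1-acetyl-1H-pyrazol-4-yl has 0 hydrogen-bond donors and 8 heavy atoms against 1 and 5 for the leaving 1H-pyrazol-3-yl, so in this pair a substituent on a pyrazole nitrogen does not go with a clear fall, which the earlier step alone (a number 28.8 percentage points lower from compound 1 to compound 3 (beyond the scatter)) could not show, as that step also exchanged a pyridin-4-yl for a pyrazole and carried a different substituent. Nothing given here offers a reason for this outcome.

The change joins two alterations in one, the acetyl on the nitrogen and the move from the 3-yl to the 4-yl attachment, and the compounds shown do not separate them, as neither 1H-pyrazol-4-yl nor 1-acetyl-1H-pyrazol-3-yl stands among them. Also open, as far as these compounds go, is how far this position accepts other groups on the pyrazole nitrogen, such as a methyl, a longer chain ending in an amine, or a carboxylic acid.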